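From Ethyl to tert-Butoxycarbonyl at the Assay Limit

A few compounds are considered here, and "the series" means these few. Any claim that something is new, unique, unknown or untested is made for them only; others in the source may bear on it.

Measured in a functional assay on MGC-803 cells (Homo sapiens) for inhibition, read by CCK-8 assay, with a stated time of 48 h; on this read-out lower numbers stand for stronger inhibition and higher numbers for weaker inhibition:
- compound 1 `COc1ccc(CN(C(=O)CSc2nc3ccccc3o2)c2cc(OC)c(OC)c(OC)c2)cc1`: 450 nM
- compound 2 `COc1ccc(CN(C(=O)CSC(=S)N2CCN(C)CC2)c2cc(OC)c(OC)c(OC)c2)cc1`: 1280 nM
- compound 3 `CCN1CCN(CC(=O)N(Cc2ccc(OC)cc2)c2cc(OC)c(OC)c(OC)c2)CC1`: > 20000 nM

The value for compound 3 is a limit of the assay and not a number.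

Compound 4 `COc1ccc(CN(C(=O)CN2CCN(C(=O)OC(C)(C)C)CC2)c2cc(OC)c(OC)c(OC)c2)cc1` has not yet been measured. It carries tert-butoxycarbonyl in place of ethyl on an amine nitrogen in a ring. For the measured compounds named here, two measured steps bear on this change: an at least 44-fold higher number from compound 1 to compound 3 (1.64 log units; beyond the scatter) and an at least 15-fold higher number from compound 2 to compound 3 (1.19 log units; beyond the scatter). Both are large, and both lead to a ring joined to the chain carbon without sulfur, a link that compound 4 keeps. As far as these compounds go, neither step changes only the group on the ring nitrogen, so this swap is untested. Compound 4 is therefore expected to stay weak in this assay, close to the limit, with no large gain. The expected size of the change is an at least 1.1-fold lower number from compound 3 to compound 4 (0.04 log units; that floor lies within the scatter) (an estimate that is uncertain in direction). For compound 4 the estimated value is 18000 nM (expected range 6000 nM to 40000 nM).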

Compound 4, half-maximal inhibitory concentration: 9500 nM
Estimate against measurement, compound 4: 1.9-fold (0.28 log units) above; the range from low to high includes it.
By their numbers in this assay, from the lowest: compound 1; then compound 2; then compound 4. At a limit, above all of these: compound 3.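

Replacing ethyl with tert-butoxycarbonyl on the ring nitrogen in this assay gives an at least 2.1-fold lower number from compound 3 to compound 4 (0.32 log units; beyond the scatter), so the group at this position does affect the read-out, even with no sulfur in the link to the chain carbon. Compound 3 gives > 20000 nM, which is a limit of the assay and not a number. The full size of the step therefore stays unknown, and it could be larger than its printed floor, because its starting point is a limit: the limit of > 20000 nM in this assay, at which 1 of the 4 values shown sits.

This pair cannot tell whether the change follows from the carbonyl on the ring nitrogen or from the added carbons of the tert-butyl part, and an acetyl or a tert-butyl group on that nitrogen would help separate the two. As far as these compounds go, how the ring would read with only a hydrogen on that nitrogen also remains open.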